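Swapping the Ring on the Thiocarbonyl Carbon

A few compounds are considered here, and "the series" means these few. Any claim that something is new, unique, unknown or untested is made for them only; others in the source may bear on it.

Compound 1 `CCOC(=O)c1cc(=O)c2cc(CSC(=S)N3CCCC3)ccc2o1` gives > 25000 nM in a functional assay on SW480 cells (Homo sapiens) for antiproliferative activity, read by MTT assay, with a stated time of 72 h (on this read-out higher numbers stand for weaker inhibition and lower numbers for stronger inhibition), which is a limit of the assay rather than a number.
Compound 2 `CCOC(=O)c1cc(=O)c2cc(CSC(=S)N3CCCCC3)ccc2o1` gives > 25000 nM in this assay, likewise only a limit.

Compound 2 therefore stands at the limit of > 25000 nM in this assay, at which 2 of the 2 values shown sit, with no exact value of its own. The step that the two limits leave unreadable from compound 1 to compound 2 cannot be read, as both ends are limits. Compound 3 `CCOC(=O)c1cc(=O)c2cc(CSC(=S)N3CCOCC3)ccc2o1` differs from compound 2 by morpholin-4-yl in place of piperidin-1-yl on a thiocarbonyl carbon. No readable measured step bears on this change, so no shift beyond the scatter is expected in this assay. Compound 3 is expected to give about 30000 nM, between 15000 nM and 80000 nM, most probably again reported only as a limit. The expected step is thus a step that the limit leaves unreadable from compound 2 to compound 3.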

Compound 3, half-maximal inhibitory concentration: > 25000 nM
Compound 3 ended at the assay's limit; the forecaster's own chance of this, stated with the estimate: 85%; the middle value is on the limit's open side.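

No step among compound 1, compound 2 and compound 3 can be read, as all three remain limits rather than numbers: the limit of > 25000 nM in this assay, at which 3 of the 3 values shown sit.

On these data alone, whether swapping these rings on the thiocarbonyl carbon changes activity at all remains open.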